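A longer chain on compound 3

This account rests on a few compounds, and the source may have more. Where it says the series, first, only, none or still open, it means among the compounds named here.

In an ADME assay on Vero cells (Chlorocebus sabaeus) for cytotoxicity, read by reporter gene assay, with a stated time of 4 days (a lower number here means a stronger inhibitor, a higher number a weaker inhibitor), compound 1 (`CCCCCCCCC(=O)OCC(C)(C)CC1=C(O)C(=O)c2ccccc2C1=O`) gives 150000 nM and compound 2 (`CCCCCCCCCC(=O)OCC(C)(C)CC1=C(O)C(=O)c2ccccc2C1=O`) gives 203000 nM. Compound 3 (`CCCCCCCCCCC(=O)OCC(C)(C)CC1=C(O)C(=O)c2ccccc2C1=O`) gives > 233000 nM, which is a limit of the assay and not a number. Compound 4 (`CCCCCCCCCCCCCC(=O)OCC(C)(C)CC1=C(O)C(=O)c2ccccc2C1=O`) differs from it by propyl in place of hydrogen on a saturated chain carbon, ten or more bonds along the chain from a carbonyl carbon, with propyl in place of hydrogen on a saturated chain carbon, ten or more bonds along the chain from a carbonyl carbon. Three measured steps on this chain bear on the change: a 1.4-fold higher number from compound 1 to compound 2 (0.13 log units; within the scatter), an at least 1.5-fold higher number from compound 1 to compound 3 (0.19 log units; that floor lies within the scatter) and an at least 1.1-fold higher number from compound 2 to compound 3 (0.05 log units; that floor lies within the scatter). All three lie within the scatter, so no step beyond it is expected in this assay. The expected change is a step that the limit leaves unreadable from compound 3 to compound 4. For compound 4 the estimate is 250000 nM, with an expected range of 130000 nM to 450000 nM.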

Compound 4, half-maximal inhibitory concentration: 58400 nM
Compound 4: the middle estimate sits 4.3-fold (0.63 log units) above what was measured; measured number outside the range, below it.
By their numbers in this assay, from the lowest: compound 4; then compounds 1 and 2 (each within the scatter of the next). At a limit, above all of these: compound 3.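

In this assay, among these compounds, propyl in place of hydrogen on a saturated chain carbon, ten or more bonds along the chain from a carbonyl carbon, gives a step beyond the scatter, an at least 3.9-fold lower number from compound 3 to compound 4 (0.60 log units; beyond the scatter), and it runs downward, which none of the earlier steps showed. The two shorter chains give the same direction, with a 3.5-fold lower number from compound 2 to compound 4 (0.54 log units; beyond the scatter) and a 2.6-fold lower number from compound 1 to compound 4 (0.41 log units; beyond the scatter). For compound 3 the figure is a limit and not a number: the limit of > 233000 nM in this assay, at which 1 of the 4 values shown sits.

The compounds shown leave open whether a still longer chain lowers the number further. They also leave open whether a chain carrying an amine would follow the same course.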